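Arylamine in place of the enol hydroxy on compound 1

The compounds below may be only part of what the source reports. "The series", "measured", "known", "first", "only" and "open" are said of these compounds alone.

Measured in a functional assay on A549 cells (Homo sapiens) for antiproliferative activity, read by MTT assay, with a stated time of 72 h; on this read-out higher numbers stand for weaker inhibition and lower numbers for stronger inhibition:
Compound 1 `O=C(C1=C(O)C(=O)N(CCCn2ccnc2)C1c1ccc(Br)cc1)c1ccccc1`: 73100 nM
Compound 2 `CCCCOC1=C(C(=O)c2ccccc2)C(c2ccc(Br)cc2)N(CCCn2ccnc2)C1=O`: 18500 nM
Compound 3 `O=C(C1=C(Nc2ccc(Br)cc2)C(=O)N(CCCn2ccnc2)C1c1ccc(Br)cc1)c1ccccc1`: 22200 nM

Compound 1 stands highest of the three numbers in this assay; the nearest is compound 3, with a 3.3-fold lower number from compound 1 to compound 3 (0.52 log units; beyond the scatter), and the furthest is compound 2, with a 4.0-fold lower number from compound 1 to compound 2 (0.60 log units; beyond the scatter). Between compounds 2 and 3 the step is a 1.2-fold higher number from compound 2 to compound 3 (0.08 log units; within the scatter).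

Compound 4 `O=C(C1=C(Nc2ccccc2Br)C(=O)N(CCCn2ccnc2)C1c1ccc(Br)cc1)c1ccccc1` differs from compound 1 by (2-bromophenyl)amino in place of hydroxy on a double-bonded ring carbon. The step that bears most directly on it is a 3.3-fold lower number from compound 1 to compound 3 (0.52 log units; beyond the scatter), which also replaced the hydroxy with an arylamine; the step of a 4.0-fold lower number from compound 1 to compound 2 (0.60 log units; beyond the scatter) points the same way. A modest lowering is therefore expected in this assay, estimated as a 2.9-fold lower number from compound 1 to compound 4 (0.47 log units; beyond the scatter). For compound 4 the expected value is 25000 nM, with a range from 8000 nM to 70000 nM.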

Compound 4, half-maximal inhibitory concentration: 20100 nM
Compound 4: middle estimate off by 1.2-fold (0.09 log units), on the high side; the range from low to high includes it.
By their numbers in this assay, from the lowest: compounds 2, 4 and 3 (each within the scatter of the next); then compound 1.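

In this assay, 2-bromophenyl and 4-bromophenyl on the amine nitrogen cannot be told apart (a 1.1-fold lower number from compound 3 to compound 4 (0.04 log units; within the scatter)). The lowering from the hydroxy recurs with this second arylamine (a 3.6-fold lower number from compound 1 to compound 4 (0.56 log units; beyond the scatter)), and (2-bromophenyl)amino reads alike with butoxy (a 1.1-fold higher number from compound 2 to compound 4 (0.04 log units; within the scatter)). No measurement at hand gives a reason for these readings.

Open is whether a bromine on the arylamine matters at all, since an unsubstituted phenylamino group is not among these compounds. Also open, on these data alone, is how a butylamino group on the double-bonded ring carbon would read against butoxy.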